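The source may hold more compounds than are shown below. What is called first, only, known or untested is meant among the compounds shown, and "the series" means these compounds.

Measured so far in a functional assay on A549 cells (Homo sapiens) for cytotoxicity, read by MTT assay, with a stated time of 48 h; a lower number here means a stronger inhibitor, a higher number a weaker inhibitor
compound 1 `CC(C)NCCOc1c(O)cc(O)c2c(=O)cc(-c3ccccc3)oc12` | "not determined" (no result reported)
compound 2 `COc1c(OCCCNCc2ccccc2)cc(O)c2c(=O)cc(-c3ccccc3)oc12` | 1570 nM
Not yet measured: compound 3 `CN(C)CCCCOc1c(O)cc(O)c2c(=O)cc(-c3ccccc3)oc12`

In this assay compound 1 has no single number, so it offers no reference point. The change to compound 3 is 2-(dimethylamino)ethyl in place of isopropylamino on a saturated chain carbon, two bonds along the chain from an oxygen on an aromatic ring on a saturated chain carbon, two bonds along the chain from an oxygen on an aromatic ring. Cut one bond further out, it reads 2-(isopropylamino)ethoxy to 4-(dimethylamino)butoxy. Among the compounds with values here, no measured step exists for this change, so no direction is expected and no step beyond the scatter is assumed in this assay from the only available number, compound 2 at 1570 nM in this series. Compound 3 is estimated at 2500 nM with an expected range from 800 nM to 9000 nM as the likely outcome.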

Compound 3, half-maximal inhibitory concentration: > 100000 nM
Compound 3 was reported as a limit; the forecaster's own chance of this, stated with the estimate: 10%; middle value at least 40-fold (1.60 log units) from the limit.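

Within the data shown here, no step from compound 1 to compound 3 can be read in this assay: compound 1 has no single number, and compound 3 stands only as a limit. The compounds shown leave open what 2-(isopropylamino)ethoxy to 4-(dimethylamino)butoxy alone does in this assay.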